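This account rests on a few compounds, and the source may have more. Where it says the series, first, only, none or still open, it means among the compounds named here.

Measured in a functional assay on HepG2 cells (Homo sapiens) for antiproliferative activity, read by MTT assay, with a stated time of 48 h; a lower number here means a stronger inhibitor, a higher number a weaker inhibitor:
- compound 1 `O=C(/C=C/c1c[nH]c2ccccc12)c1ccncc1`: 49300 nM
- compound 2 `Cc1ccc(S(=O)(=O)n2cc(/C=C/C(=O)c3ccncc3)c3ccccc32)cc1`: 44800 nM
- compound 3 `COc1ccc(S(=O)(=O)n2cc(/C=C/C(=O)c3ccncc3)c3ccccc32)cc1`: 26000 nM

The value of compound 3 lies within the scatter of those of compound 1 and compound 2, so it stands apart from neither. Compound 4 `O=C(/C=C/c1cn(S(=O)(=O)c2ccc(Cl)cc2Cl)c2ccccc12)c1ccncc1` carries 2,4-dichlorophenyl in place of 4-methoxyphenyl on a sulfonyl sulfur. Among the measured compounds shown here, only one measured step bears on this site, a 1.7-fold lower number from compound 2 to compound 3 (0.24 log units; within the scatter), where methoxy replaces methyl on an aromatic carbon, and it stays within the scatter. For the measured compounds named here, it offers no measured precedent for a chlorine-bearing ring, so no step beyond the scatter is expected in this assay, and no direction is favoured. The expected change is a 1.0-fold lower number from compound 3 to compound 4 (0.02 log units; within the scatter). For compound 4 the estimated value is 25000 nM, with an expected range of 10000 nM to 55000 nM.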

Compound 4, half-maximal inhibitory concentration: 14800 nM
The estimate for compound 4 lay 1.7-fold (0.23 log units) above the measured number; measured number inside the range.
By their numbers in this assay, from the lowest: compounds 4, 3, 2 and 1 (each within the scatter of the next, the first and the last beyond it).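

Among the compounds shown here, with 2,4-dichlorophenyl on the sulfonyl sulfur, this assay shows the first step at this site beyond the scatter, a 3.0-fold lower number from compound 2 to compound 4 (0.48 log units; beyond the scatter), though it is a modest one. Against 4-methoxyphenyl, the same group gives a 1.8-fold lower number from compound 3 to compound 4 (0.24 log units; within the scatter), so the gain is seen only against 4-methylphenyl. Nothing available accounts for either step. The compounds shown leave open whether a single chlorine on this ring would give the same step. They also leave open how a ring bearing an amine or a carboxylic acid would read here.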